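Dimethoxyphenyl in place of dichlorophenyl on compound 1

A few compounds are considered here, and "the series" means these few. Any claim that something is new, unique, unknown or untested is made for them only; others in the source may bear on it.

In a functional assay on U-87MG ATCC cells for antiproliferative activity against U-87 MG (Homo sapiens), read by MTT assay, with a stated time of 48 h (on this read-out higher numbers stand for weaker inhibition and lower numbers for stronger inhibition), compound 1 (`Cc1nc(-c2ccc(Cl)cc2)sc1C(=O)CSc1nc(-c2ccc(Cl)c(Cl)c2)c(C#N)c(=O)[nH]1`) gives 83900 nM and compound 2 (`Cc1nc(-c2ccccc2)sc1C(=O)CSc1nc(-c2ccc(Cl)c(Cl)c2)c(C#N)c(=O)[nH]1`) gives 65000 nM, so the two sit together at the high end of the numbers. Compound 3 (`Cc1nc(-c2ccccc2)sc1C(=O)CSc1nc(N)c(C#N)c(-c2ccccc2)n1`) gives 29000 nM, beyond the scatter from compound 1. Compound 4 (`COc1ccc(-c2nc(SCC(=O)c3sc(-c4ccc(Cl)cc4)nc3C)[nH]c(=O)c2C#N)cc1OC`) differs from compound 1 in one place: 3,4-dimethoxyphenyl in place of 3,4-dichlorophenyl on an aromatic carbon. Among the measured compounds shown here, only one measured step bears on this, a 1.3-fold lower number from compound 1 to compound 2 (0.11 log units; within the scatter), and it lies on the other aromatic ring and stays within the scatter. For the measured compounds named here, no measured step touches the 3,4-dichlorophenyl group itself, so the evidence is thin. No shift beyond the scatter is expected, and the estimated step is a 1.3-fold lower number from compound 1 to compound 4 (0.11 log units; within the scatter). Compound 4 is estimated at 65000 nM, with an expected range of 27000 nM to 150000 nM.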

Compound 4, half-maximal inhibitory concentration: 38600 nM
Compound 4: middle estimate off by 1.7-fold (0.23 log units), on the high side; low and high end bracket the measured number.
By their numbers in this assay, from the lowest: compounds 3, 4, 2 and 1 (each within the scatter of the next, the first and the last beyond it).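

In this assay, 3,4-dimethoxyphenyl in place of 3,4-dichlorophenyl gives a 2.2-fold lower number from compound 1 to compound 4 (0.34 log units; beyond the scatter), so a single change at this position moves the number beyond the scatter. Among the compounds shown here, the only earlier single-place step, on the other aromatic ring, stayed within it. No measured property at hand accounts for this shift. The compounds shown leave open whether a single methoxy group, a hydroxy group or an amine on this phenyl ring would give a similar number, and whether the same change would hold on compound 2.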